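Cytotoxicity notes: fluoro for methoxy on the pendant ring

The source may hold more compounds than are shown below. What is called first, only, known or untested is meant among the compounds shown, and "the series" means these compounds.

Of the compounds shown here, two have been measured so far. Compound 1 `COc1cccc(-c2cc(=O)c3cc(NC(C)=O)ccc3o2)c1` gives 10000 nM in an ADME assay on THP-1 cells (Homo sapiens) for cytotoxicity, read by flow cytometry and propidium iodide staining, with a stated time of 72 h; on this read-out lower numbers stand for stronger inhibition and higher numbers for weaker inhibition. Going by the values given here, compound 2 `COc1cccc(-c2oc3ccc(NC(C)=O)cc3c(=O)c2O)c1`, which carries a hydroxy in place of hydrogen on an aromatic carbon, gives 50000 nM and stands as the higher of the two numbers; the only measured step is a 5.0-fold higher number from compound 1 to compound 2 (0.70 log units; beyond the scatter). Compound 3 `CC(=O)Nc1ccc2oc(-c3cccc(F)c3)c(O)c(=O)c2c1` is not yet measured. It differs from compound 2 by fluoro in place of methoxy on an aromatic carbon. Among the compounds with values here, no measured step touches the 3-methoxyphenyl part of the core, so the one step in hand, which concerns the hydroxy, does not bear on this change, and the default expectation is a step no larger than the scatter in this assay. Compound 3 is therefore expected to sit near 50000 nM, within 20000 nM to 125000 nM, an expected step of no change at the digits printed from compound 2 to compound 3 (within the scatter).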

Compound 3, half-maximal inhibitory concentration: 36000 nM
The estimate for compound 3 lay 1.4-fold (0.14 log units) above the measured number; the measured number falls inside the stated range.
By their numbers in this assay, from the lowest: compound 1; then compounds 3 and 2 (each within the scatter of the next).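

In this assay, going by these compounds alone, the change from 3-methoxyphenyl to 3-fluorophenyl, with the hydroxy kept, gives a 1.4-fold lower number from compound 2 to compound 3 (0.14 log units; within the scatter) and is the first reading at this position on the pendant ring. For these two compounds, the smaller fluoro can stand in place of methoxy on this aromatic carbon without a step beyond the scatter, whereas the hydroxy step gives a 5.0-fold higher number from compound 1 to compound 2 (0.70 log units; beyond the scatter) and remains the only listed step beyond it. No measurement on hand bears on the reason for this result.

The compounds shown leave open whether an amine or a carboxylic acid on the same aromatic carbon would give a step beyond the scatter. They also leave open whether fluoro in place of methoxy gives a similar step on the core of compound 1, which lacks the hydroxy.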